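Swapping a Benzyl for a Methylphenyl on the Core

A few compounds are considered here, and "the series" means these few. Any claim that something is new, unique, unknown or untested is made for them only; others in the source may bear on it.

Three compounds share one core and one assay. Compound 1 `C=C(Br)C(=O)Nc1cccc(-c2cn3nc(-c4ccc(F)cc4)sc3n2)c1` gives 610 nM in a functional assay on FM3A cells (Mus musculus) for inhibition, read by cell counting, with a stated time of 2 days; a lower number here means a stronger inhibitor, a higher number a weaker inhibitor; compound 2 `C=C(Br)C(=O)Nc1cccc(-c2cn3nc(-c4ccccc4)sc3n2)c1` gives 900 nM; compound 3 `C=C(Br)C(=O)Nc1cccc(-c2cn3nc(Cc4ccc(Cl)cc4)sc3n2)c1` gives 1100 nM. Compound 3 holds the highest of the three numbers, yet the steps of a 1.2-fold higher number from compound 2 to compound 3 (0.09 log units; within the scatter) and a 1.8-fold higher number from compound 1 to compound 3 (0.26 log units; within the scatter) both lie within the scatter, so no order among them can be read. Compound 4 `C=C(Br)C(=O)Nc1cccc(-c2cn3nc(-c4ccc(C)cc4)sc3n2)c1` differs from compound 3 by 4-methylphenyl in place of 4-chlorobenzyl on an aromatic carbon. The steps of a 1.8-fold higher number from compound 1 to compound 3 (0.26 log units; within the scatter) and a 1.2-fold higher number from compound 2 to compound 3 (0.09 log units; within the scatter) bear on this, as each puts the 4-chlorobenzyl in place of a 4-fluorophenyl or a phenyl; both were small. A slightly lower number is therefore expected, not beyond the scatter. Compound 4 is estimated at 750 nM, ranging from 350 nM to 1600 nM. The expected step is a 1.5-fold lower number from compound 3 to compound 4 (0.17 log units; within the scatter).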

Compound 4, half-maximal inhibitory concentration: 1200 nM
Compound 4: the middle estimate sits 1.6-fold (0.20 log units) below what was measured, within the range that was stated.
By their numbers in this assay, from the lowest: compounds 1, 2, 3 and 4 (each within the scatter of the next).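

Putting a methyl on the phenyl ring changes nothing that can be read in this assay (a 1.3-fold higher number from compound 2 to compound 4 (0.12 log units; within the scatter)), and neither does methyl in place of fluoro (a 2.0-fold higher number from compound 1 to compound 4 (0.29 log units; within the scatter)) or 4-methylphenyl in place of 4-chlorobenzyl (a 1.1-fold higher number from compound 3 to compound 4 (0.04 log units; within the scatter)). The four groups on this aromatic carbon, next to the ring sulfur, therefore cannot be told apart, though each carries a six-membered aromatic ring of carbon only. No evidence is at hand to explain this. The compounds shown leave open whether an amine, a carboxylic acid or a longer chain at this position would separate from them.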